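This account rests on a few compounds, and the source may have more. Where it says the series, first, only, none or still open, it means among the compounds named here.

Compound 1 `CCOCCOc1cccc2ccc(N)nc12` stands at a limit of the assay rather than at a number: in an assay on cells with melanin-concentrating hormone receptor 1 (Homo sapiens) as the target, read by radioligand binding (on this read-out lower numbers stand for stronger inhibition and higher numbers for weaker inhibition), compound 1 gives > 2000 nM. Two of the three values shown sit at that limit (the limit of > 2000 nM in this assay, at which 2 of the 3 values shown sit). Compound 2 `Nc1ccc2cccc(OCCC3CCCCC3)c2n1` carries a cyclohexyl where compound 1 carries ethoxy; in this assay compound 2 gives 808 nM. Compound 3 `Nc1ccc2cccc(OCC3CC3)c2n1` also sits at a limit of the assay, giving > 2000 nM in this assay. The step of an at least 2.4-fold lower number from compound 1 to compound 2 (0.39 log units; beyond the scatter) is the only one that can be read; the step that the two limits leave unreadable from compound 1 to compound 3 cannot, since both ends are limits.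

Compound 4 `CC(C)(C)CCOc1cccc2ccc(N)nc12` differs from compound 1 in one place: tert-butyl in place of ethoxy on a saturated chain carbon, two bonds along the chain from an oxygen on an aromatic ring. Like the cyclohexyl of compound 2, the entering tert-butyl is a saturated carbon group without an oxygen, though smaller, so a step similar in direction to an at least 2.4-fold lower number from compound 1 to compound 2 (0.39 log units; beyond the scatter) but no larger is expected, with a real chance that only a limit is reported again. Compound 4 is therefore estimated at 1500 nM, within 500 nM to 4500 nM, which is an expected step of an at least 1.3-fold lower number from compound 1 to compound 4 (0.12 log units; that floor lies within the scatter).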

Compound 4, half-maximal inhibitory concentration: 201 nM
Estimate against measurement, compound 4: 7.5-fold (0.87 log units) above; the measured number lies below the stated range.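

In this assay, tert-butyl in place of ethoxy gives an at least 9.9-fold lower number from compound 1 to compound 4 (0.99 log units; beyond the scatter), and neopentyl in place of cyclopropyl gives an at least 9.9-fold lower number from compound 3 to compound 4 (0.99 log units; beyond the scatter). Both steps are floors rather than full sizes, since compound 1 and compound 3 each stand at a limit of the assay: the limit of > 2000 nM in this assay, at which 2 of the 4 values shown sit. The comparison of the two oxygen-free groups at this place is new: tert-butyl in place of cyclohexyl gives a 4.0-fold lower number from compound 2 to compound 4 (0.60 log units; beyond the scatter), so a carbon group without oxygen is not all that counts here, and the ring-free tert-butyl of compound 4 outdoes the cyclohexyl of compound 2.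

On these data alone, how an isopropyl or a straight butyl chain in the same place would compare with tert-butyl stays open. So does the effect of an amine or a carboxylic acid there.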